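The source may hold more compounds than are shown below. What is called first, only, known or untested is meant among the compounds shown, and "the series" means these compounds.

Three compounds share one core and differ only in what sits on the outer aromatic ring. Compound 1 `O=C(Nc1ccccc1)c1ccc(C(=O)O)nc1` carries no substituent there, and in an assay on isolated protein (Gallus gallus) for inhibition of transmembrane prolyl 4-hydroxylase (Homo sapiens) (on this read-out higher numbers stand for weaker inhibition and lower numbers for stronger inhibition), compound 1 gives 26500 nM. Compound 2 `O=C(Nc1ccccc1Cl)c1ccc(C(=O)O)nc1` carries a chloro group, and in this assay compound 2 gives 16300 nM. Compound 3 `O=C(Nc1ccc(F)cc1)c1ccc(C(=O)O)nc1` carries a fluoro group, and in this assay compound 3 gives 16100 nM. The three numbers sit close together: a 1.6-fold lower number from compound 1 to compound 2 (0.21 log units; within the scatter) and a 1.6-fold lower number from compound 1 to compound 3 (0.22 log units; within the scatter), so compound 3 cannot be told apart from compound 2 or compound 1 on these data.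

The next compound, compound 4 `Cc1ccc(NC(=O)c2ccc(C(=O)O)nc2)cc1`, is reached from compound 3 by methyl in place of fluoro on an aromatic carbon. Among the measured compounds shown here, no measured step exchanges one substituent for another; the two known steps, both within the scatter, only show that adding a small group to this ring leaves the number about where it was. On that basis the expected step is a 1.0-fold lower number from compound 3 to compound 4 (0.00 log units; within the scatter), that is, no change beyond the scatter. Compound 4 is therefore estimated at 16000 nM, expected to fall between 8000 nM and 35000 nM.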

Compound 4, half-maximal inhibitory concentration: 8300 nM
Compound 4: middle estimate off by 1.9-fold (0.29 log units), on the high side; low and high end bracket the measured number.
By their numbers in this assay, from the lowest: compounds 4, 3, 2 and 1 (each within the scatter of the next, the first and the last beyond it).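

Replacing fluoro with methyl on this aromatic carbon, para to a large group, gives a 1.9-fold lower number from compound 3 to compound 4 (0.29 log units; within the scatter), so these two groups cannot be told apart here. Compared with hydrogen at the same place, however, methyl gives a 3.2-fold lower number from compound 1 to compound 4 (0.50 log units; beyond the scatter), the first step in this series to clear the scatter: a modest gain in inhibition, but evidence that a substituent on this carbon can change the result, which adding fluoro alone did not show. Nothing available here explains this step. Going by these compounds, whether an amine, a carboxylic acid or a longer chain at this place would strengthen or weaken inhibition remains open. Also open, on these data alone, is how methyl would behave on the other carbons of this ring.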